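A few compounds are considered here, and "the series" means these few. Any claim that something is new, unique, unknown or untested is made for them only; others in the source may bear on it.

Working notes on the thiosemicarbazone series.

Three members have been measured in a functional assay on MIA PaCa-2 cells (Homo sapiens) for cytotoxicity, read by luminescence, with a stated time of 72 h; on this read-out higher numbers stand for weaker inhibition and lower numbers for stronger inhibition. Compound 1 `CN(C)C(=S)NN=Cc1nccc2ccccc12` gives 29600 nM in this assay. Compound 2 `CNC(=S)N/N=C/c1nccc2ccccc12`, which carries a single methyl on the thioamide nitrogen, gives 18700 nM in this assay; the values of compound 1 and compound 2 lie close to one another, within the usual scatter. For the measured compounds named here, compound 3 `CNC(=S)N/N=C/c1ncc(F)c2ccccc12` is the fluorinated analogue of compound 2; in this assay compound 3 gives 2080 nM and stands lowest of the three numbers; the only single-point step measured so far is a 9.0-fold lower number from compound 2 to compound 3 (0.95 log units; beyond the scatter), which carries compound 3 clearly below the other two.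

The next member is compound 4 `NC(=S)N/N=C/c1ncc(F)c2ccccc12`. The change from compound 3 is hydrogen in place of methyl on an amide-type nitrogen, that is, methylamino to amino. Going by the values given here, no measured step covers this change directly; the nearest comparison is the pair compound 1 and compound 2, which differ only in substitution on that same nitrogen and show values within scatter of each other. On that basis no step beyond the scatter is expected in this assay for compound 4, with the fluoro retained from compound 3. The step of a 1.1-fold higher number from compound 3 to compound 4 (0.02 log units; within the scatter) is therefore estimated as essentially flat. Compound 4 is expected to give about 2200 nM, within a range of 700 nM to 7000 nM.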

Compound 4, concentration for 90% inhibition: 24600 nM
The estimate for compound 4 lay 11-fold (1.05 log units) below the measured number; the measured number lies above the stated range.
By their numbers in this assay, from the lowest: compound 3; then compounds 2, 4 and 1 (each within the scatter of the next).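

In this assay the change from methylamino to amino on the amide-type nitrogen, with the fluoro retained, gives a 12-fold higher number from compound 3 to compound 4 (1.07 log units; beyond the scatter) and shows that this nitrogen is not indifferent to its substitution. The earlier comparison at the same nitrogen, compound 1 at 29600 nM against compound 2 at 18700 nM, stayed within the scatter, so the flat result there does not carry over to the change from methylamino to amino, and the methyl of compound 3 counts for much of its standing as the lowest number in the series. Nothing available here speaks to why this step is so large.

The compounds shown leave open whether the methyl counts as much on the core without the fluoro, since the change from methylamino to amino is seen only with the fluoro in place, and the two nitrogen comparisons therefore stand on different cores. They also leave open how the value responds to an ethyl group or a longer chain on that nitrogen, or to a cyclic amine such as morpholine in its place, so the trend cannot yet be read beyond methyl and hydrogen.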